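Replacing Trimethoxyphenyl with a Phenol on a Chlorinated Core

The source may hold more compounds than are shown below. What is called first, only, known or untested is meant among the compounds shown, and "the series" means these compounds.

Compound 1, `CCN(CC)CCCn1c(=O)/c(=C/c2ccc(F)cc2F)s/c1=C1\C(=O)Nc2cc(F)ccc21`: 4120 nM
Compound 2, `CCN(CC)CCCn1c(=O)/c(=C/c2cc(OC)c(OC)c(OC)c2)s/c1=C1\C(=O)Nc2ccc(Cl)cc21`: 1650 nM
Compound 3, `CCN(CC)CCCn1c(=O)/c(=C/c2ccc(F)c(F)c2)s/c1=C1\C(=O)Nc2ccc(F)cc21`: 6480 nM

Three compounds were tested in a functional assay on K562/Adr cells (Homo sapiens) for cytotoxicity, read by sulforhodamine B assay, with a stated time of 48 h; a lower number here means a stronger inhibitor, a higher number a weaker inhibitor. Compound 2 holds the lowest number of the three, and its distances to compound 1 and to compound 3 both lie beyond the scatter, so within this set it is the most potent. Compound 4, `CCN(CC)CCCn1c(=O)/c(=C/c2ccc(O)cc2)s/c1=C1\C(=O)Nc2ccc(Cl)cc21`, has not yet been measured. It differs from compound 2 by 4-hydroxyphenyl in place of 3,4,5-trimethoxyphenyl on a double-bonded chain carbon bound to an aromatic carbon. For the measured compounds named here, no measured pair shows this change, so its effect is uncertain. The step from compound 2 to compound 4 is expected to be a moderate weakening, a 2.0-fold higher number from compound 2 to compound 4 (0.30 log units; within the scatter). Compound 4 is therefore expected to give about 3300 nM in this assay, somewhere between 1000 nM and 10000 nM.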

Compound 4, half-maximal inhibitory concentration: 48800 nM
Compound 4: the middle estimate sits 15-fold (1.17 log units) below what was measured, and the stated range ends below it.
By their numbers in this assay, from the lowest: compound 2; then compounds 1 and 3 (each within the scatter of the next); then compound 4.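

In this assay, 4-hydroxyphenyl in place of 3,4,5-trimethoxyphenyl on a double-bonded chain carbon bound to an aromatic carbon gives a 30-fold higher number from compound 2 to compound 4 (1.47 log units; beyond the scatter). This is the first change in one place among these compounds, and it shows that the group held here can strongly shift the number on the shared core. As far as these compounds go, whether the step comes from the loss of the methoxy groups or from the gain of the hydroxyl stays open, and a 4-methoxyphenyl group here would bear on that question. No measurement at hand explains the size of this step.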